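A few compounds are considered here, and "the series" means these few. Any claim that something is new, unique, unknown or untested is made for them only; others in the source may bear on it.

Measured so far in a functional assay on PC-12 cells (Rattus norvegicus) for cytotoxicity, read by MTT assay, with stated times of 2 h and 24 h, tested at 10 uM; on this read-out higher numbers stand for a stronger effect at the one concentration tested and lower numbers for a weaker effect:
compound 1 `CC(C)c1ccc(-n2nc(-c3ccc(C(F)(F)F)cc3O)nc2-c2ccccc2O)cc1`: 108%
compound 2 `COc1ccccc1-n1nc(-c2ccc(C(F)(F)F)cc2O)nc1-c1ccccc1O`: 96.2%

Compound 2 gives the lower of the two numbers. Within the data shown here, the only measured step, a number 11.8 percentage points lower from compound 1 to compound 2 (beyond the scatter), also swaps the group on the aromatic nitrogen, so it is the one that bears here. Compound 3 `Oc1cc(C(F)(F)F)ccc1-c1nc(-c2ccccc2O)n(-c2cccc(F)c2)n1` differs from compound 2 by 3-fluorophenyl in place of 2-methoxyphenyl on an aromatic nitrogen. Among the measured compounds shown here, no measured step matches this exact exchange, and the one that exists was only modest, so a change of at most similar size is expected, with no clear direction. For compound 3 a step of about a number 0.8 percentage points higher from compound 2 to compound 3 (within the scatter) is expected, giving an estimated 97%, within 82% to 112%.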

Compound 3, a percentage reported as activity, at one concentration (the size of the read-out at that concentration, not a potency): 98.3%
Estimate against measurement, compound 3: 1.3 percentage points below; the range from low to high includes it.
By their numbers in this assay, from the lowest: compounds 2, 3 and 1 (each within the scatter of the next, the first and the last beyond it).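

In this assay, 3-fluorophenyl and 2-methoxyphenyl on this aromatic nitrogen cannot be told apart: the exchange gives a number 2.1 percentage points higher from compound 2 to compound 3 (within the scatter) and so shows no real effect. The step with a number 9.7 percentage points lower from compound 1 to compound 3 (within the scatter) also stays inside the scatter, so compound 3 sits close to both other compounds, although compound 1 and compound 2 differ beyond it. Nothing available explains these numbers. Still open, from the compounds shown here alone, is whether a phenyl ring carrying an amine or a carboxylic acid on this nitrogen would move the read-out beyond the scatter.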